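The compounds below may be only part of what the source reports. "The series", "measured", "known", "first", "only" and "open" are said of these compounds alone.

Measured so far:
compound 1 `CCOc1cc(/C=N/n2cnnc2)ccc1OC`: 5220 nM in an assay for inhibition of Alpha amylase (Homo sapiens), with a stated time of 10 min; a higher number here means a weaker inhibitor, a lower number a stronger inhibitor
compound 2 `COc1ccc(/C=N/n2cnnc2)c(F)c1`: 2900 nM

Compound 1 carries the higher of the two numbers, yet compound 2 sits within the usual scatter of it, so the two cannot be told apart on these data. Compound 3 `COc1ccc(/C=N/n2cnnc2)cc1OCc1ccccc1` differs from compound 1 by phenyl in place of methyl on a saturated chain carbon bound to an oxygen on an aromatic ring. Among the measured compounds shown here, no measured pair shows this change, so its size can only be guessed. Compound 3 is expected to move by a 1.5-fold lower number from compound 1 to compound 3 (0.17 log units; within the scatter) in this assay, a small step downward that may not exceed the scatter. Compound 3 is therefore estimated at 3500 nM, within a range of 1200 nM to 11000 nM.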

Compound 3, half-maximal inhibitory concentration: 6230 nM
For compound 3 the middle estimate is 1.8-fold (0.25 log units) below the measured one; the measured number falls inside the stated range.
By their numbers in this assay, from the lowest: compounds 2, 1 and 3 (each within the scatter of the next, the first and the last beyond it).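

The step of phenyl in place of methyl on a saturated chain carbon bound to an oxygen on an aromatic ring reads a 1.2-fold higher number from compound 1 to compound 3 (0.08 log units; within the scatter) in this assay and leaves compound 1 and compound 3 indistinguishable. This position thus carries either the ethyl of compound 1 or the much larger benzyl of compound 3 with no readable difference in this measure. No supporting data bear on why this is so.

As far as these compounds go, whether an amine, a carboxylic acid or a longer chain at this place would also read the same remains open. So does whether a substituted benzyl would.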